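The source may report more compounds than this note shows. Statements on the series, on what has been measured and on what is new or still open speak of the compounds shown alone.

Measured in an ADME assay on a cell-free system (plasma, Mus musculus); on this read-out lower numbers stand for a smaller free fraction and higher numbers for a larger free fraction:

- compound 1 `CN(C)S(=O)(=O)c1ccc(F)c(C#Cc2cc(Cl)ccc2OCC(=O)O)c1`: 0.029
- compound 2 `Cc1ccc(S(=O)(=O)N(C)C(C)C)cc1C#Cc1cc(Cl)ccc1OCC(=O)O`: 0.005
- compound 3 `COCCNS(=O)(=O)c1ccc(C)c(C#Cc2cc(Cl)ccc2OCC(=O)O)c1`: "not determined" (no result reported)

Compound 3 has no number on this read-out, so it offers no starting value for the next step. The change to compound 4 `Cc1ccc(S(=O)(=O)N(C)C)cc1C#Cc1cc(Cl)ccc1OCC(=O)O` puts dimethylamino in place of (2-methoxyethyl)amino on a sulfonyl sulfur. With no value at the compound 3 end, neither a size nor a direction can be expected for this step in this assay, and the expectation has to come from the two measured compounds. Compound 1 gives 0.029 and carries the same dimethylamino on a sulfonyl sulfur as compound 4. Compound 2 gives 0.005, a lower value than that of compound 1, and the two values set the likely span. A value for compound 4 inside that span is expected, without a firm lean towards either end. The estimate for compound 4 is 0.015 with an expected range from 0.006 to 0.035 on this read-out.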

Compound 4, unbound fraction: 0.01
The estimate for compound 4 lay 1.5-fold (0.18 log units) above the measured number; low and high end bracket the measured number.
By their numbers in this assay, from the lowest: compounds 2 and 4 (each within the scatter of the next); then compound 1.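

In this assay, a 2.0-fold higher number from compound 2 to compound 4 (0.30 log units; within the scatter) stays within the usual scatter, so methyl in place of isopropyl on a sulfonamide nitrogen gives no readable shift in this pair. By contrast, a 2.9-fold lower number from compound 1 to compound 4 (0.46 log units; beyond the scatter) lies beyond the scatter, a modest step, so methyl in place of fluoro on an aromatic carbon does register on this read-out in this pair. The step from compound 3 cannot be read, and no accompanying measurement offers an explanation for either readable step.

Still open, on these data alone, is how this assay responds to a cyclic amine such as morpholine on a sulfonyl sulfur. Also open, as far as these compounds go, is whether a nitrile on that aromatic carbon would give a number closer to that of compound 1 or compound 4.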